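Nucleoside series: benzofuranyl replacing thiophenyl on the shared core

The source may hold more compounds than are shown below. What is called first, only, known or untested is meant among the compounds shown, and "the series" means these compounds.

Among the compounds with values here, compound 1 `COc1ncnc2c1c(-c1ccsc1)cn2[C@@H]1O[C@H](CO)[C@@H](O)[C@H]1O` is the only member of this set with a number rather than a limit; in a functional assay on A549 cells (Homo sapiens), read by MTT assay, with a stated time of 72 h (a higher number here means a weaker inhibitor, a lower number a stronger inhibitor), compound 1 gives 5170 nM. Compound 2 `CSc1ncnc2c1c(-c1ccsc1)cn2[C@@H]1O[C@H](CO)[C@@H](O)[C@H]1O` sits at a limit of the assay: in this assay compound 2 gives > 20000 nM. Within the data shown here, the one measured step is an at least 3.8-fold higher number from compound 1 to compound 2 (0.58 log units; beyond the scatter), and its size rests on (the limit of > 20000 nM in this assay, at which 1 of the 2 values shown sits).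

Compound 3 `COc1ncnc2c1c(-c1cc3ccccc3o1)cn2[C@@H]1O[C@H](CO)[C@@H](O)[C@H]1O` differs from compound 1 by 1-benzofuran-2-yl in place of thiophen-3-yl on an aromatic carbon. The measured step from compound 1 to compound 2 concerns the methoxy group and not the thiophen-3-yl group, so it bears on this change only as a sign that the core tolerates little variation without loss. No direct guidance exists for the new group. The expectation is therefore a step near the scatter, with wide uncertainty and a fair chance of a limit; compound 3 is estimated at 4500 nM, between 900 nM and 20000 nM, which means an expected 1.1-fold lower number from compound 1 to compound 3 (0.06 log units; within the scatter).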

Compound 3, half-maximal inhibitory concentration: 17700 nM
The estimate for compound 3 lay 3.9-fold (0.59 log units) below the measured number, within the range that was stated.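

The place held by thiophen-3-yl on the shared core is not indifferent to the group it carries: in this assay, 1-benzofuran-2-yl in its place gives a 3.4-fold higher number from compound 1 to compound 3 (0.53 log units; beyond the scatter). The earlier compounds shown here showed a loss only on changing the methoxy group, so this aromatic carbon of the five-membered ring is a second place where a single change moves the number beyond the scatter. The loss is modest, and compound 3 still gives a number, 17700 nM, rather than a limit.

The change swaps sulfur for oxygen and adds a six-membered aromatic ring together, so the shared series leaves open which of the two carries the step, a question that a furan-2-yl or a benzothiophen-2-yl group at this place would separate. Compound 2 stays at a limit, and how the methoxy step compares in size with this one cannot be read because of it: the limit of > 20000 nM in this assay, at which 1 of the 3 values shown sits.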